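The source may hold more compounds than are shown below. What is called first, only, known or untested is meant among the compounds shown, and "the series" means these compounds.

In an ADME assay on HepG2 cells (Homo sapiens) for cytotoxicity, read by resazurin assay, with a stated time of 48 h (a higher number here means that more compound is needed for the effect, a lower number that less compound is needed), compound 3 (`O=C(Nc1ccc(F)c(-c2nc3ncc(-c4ccc(O)cc4)cc3[nH]2)c1)N1CCCC1`) gives > 50000 nM, which is a limit of the assay and not a number. Compound 1 (`O=C(Nc1ccc(F)c(-c2nc3ncc(-c4cccc(F)c4F)cc3[nH]2)c1)N1CCCC1`) gives > 50000 nM, which is also a limit. Compound 2 (`O=C(Nc1ccc(F)c(-c2nc3ncc(-c4cccnc4F)cc3[nH]2)c1)N1CCCC1`) gives > 50000 nM, again a limit. The whole of the evidence so far is the limit of > 50000 nM in this assay, at which 3 of the 3 values shown sit, so compound 3 stands with the other two and has no numerical value of its own.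

The step to compound 4 (`O=C(Nc1ccc(F)c(-c2nc3ncc(-c4cccc(F)c4)cc3[nH]2)c1)N1CCCC1`) places 3-fluorophenyl in place of 4-hydroxyphenyl on an aromatic carbon of the same six-membered aromatic ring with 1 nitrogen: 3-fluorophenyl in place of 4-hydroxyphenyl on an aromatic carbon. Three measured steps change the group at this position. They are a step that the two limits leave unreadable from compound 1 to compound 3, a step that the two limits leave unreadable from compound 2 to compound 3 and a step that the two limits leave unreadable from compound 1 to compound 2. None of them has a readable size, so they offer no measured magnitude to carry over, but none of the three compounds has left the limit of the assay either. On that basis, no change beyond the usual scatter is expected in this assay, in either direction. The expected step is a number no higher from compound 3 to compound 4 (the limit leaves the size open). Compound 4 is estimated at 50000 nM, with an expected range of 30000 nM to 70000 nM, and it will most likely be reported only as a limit.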

Compound 4, half-maximal effective concentration: 28200 nM
Beside the measured number, compound 4's estimate is 1.8-fold (0.25 log units) above it, and the stated range ends above it.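

In this assay compound 4 is the first of the compounds shown to give a number and not a limit, so the group at this position can bring a value into the readable range of the assay. The steps that can now be read are an at least 1.7-fold lower number from compound 3 to compound 4 (0.24 log units; that floor lies within the scatter), an at least 1.7-fold lower number from compound 2 to compound 4 (0.24 log units; that floor lies within the scatter) and an at least 1.7-fold lower number from compound 1 to compound 4 (0.24 log units; that floor lies within the scatter); each is only a floor that lies within the scatter, so none of them yet shows a shift beyond it, although the true sizes may be larger. The step from compound 1 is the narrowest of the three, hydrogen in place of a single fluoro, and it is enough to separate a number from a limit, yet that single number stands against a background still dominated by the limit: the limit of > 50000 nM in this assay, at which 3 of the 4 values shown sit.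

As far as these compounds go, how far the values of compounds 1, 2 and 3 lie from that of compound 4 remains open, and so does whether the gap exceeds the scatter at all. The compounds shown also leave open how an amine, a carboxylic acid or an unsubstituted phenyl at this position would read in this assay.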